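The source may hold more compounds than are shown below. What is called first, only, known or untested is meant among the compounds shown, and "the series" means these compounds.

Measured compounds:
compound 1 `COc1ccccc1CN(C)C(=O)c1c(-c2ccc(F)cc2)c2cccnc2c(=O)n1C`, 2.5 nM
compound 2 `Cc1cc2c(-c3ccccc3)c(NC(=O)N(C)Cc3ccccc3Cl)n(C)c(=O)c2cc1C`, 4.2 nM
compound 3 `COc1ccccc1CN(C)C(=O)Nc1c(-c2ccccc2)c2cc(C)c(C)cc2c(=O)n1C`, 23 nM

The three compounds were tested in an assay on IM-9 cells for binding affinity to Substance-P receptor (Homo sapiens); on this read-out higher numbers stand for weaker inhibition and lower numbers for stronger inhibition. In this assay compound 1 gives 2.5 nM, compound 2 gives 4.2 nM and compound 3 gives 23 nM. Compound 1 and compound 2 lie within the scatter of each other, while compound 3 stands clearly apart from both. Among the measured compounds shown here, the one counted step among them is chloro in place of methoxy on an aromatic carbon, which gives a 5.5-fold lower number from compound 3 to compound 2 (0.74 log units; beyond the scatter). The difference between the core of compound 1 and the core of compound 3 is not broken down here.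

Compound 4 `CN(Cc1ccccc1Cl)C(=O)c1c(-c2ccc(F)cc2)c2cccnc2c(=O)n1C` has not yet been measured. It differs from compound 1 by chloro in place of methoxy on an aromatic carbon, the same change that was made from compound 3 to compound 2. Because compound 3 to compound 2 gave a 5.5-fold lower number from compound 3 to compound 2 (0.74 log units; beyond the scatter), a step in the same direction is expected for compound 4, though compound 1 already gives 2.5 nM, so a smaller gain is estimated: a 2.1-fold lower number from compound 1 to compound 4 (0.32 log units; beyond the scatter). In this assay compound 4 is expected to give 1.2 nM, estimated between 0.4 nM and 4 nM.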

Compound 4, half-maximal inhibitory concentration: 32 nM
Beside the measured number, compound 4's estimate is 27-fold (1.43 log units) below it; measured number above the stated range.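

In this assay, going from 2-methoxybenzyl to 2-chlorobenzyl on the core of compound 1 gives a 13-fold higher number from compound 1 to compound 4 (1.11 log units; beyond the scatter). Set beside the earlier step, the same change does not carry over from one core to the other, even in direction: the same change on two cores in this assay, a 5.5-fold lower number (0.74 log units; beyond the scatter) from compound 3 to compound 2 and a 13-fold higher number (1.11 log units; beyond the scatter) from compound 1 to compound 4, 70-fold (1.85 log units) apart, beyond the scatter of two such steps This shows that in this series the outcome of exchanging methoxy for chloro depends on the core that carries it, so a step read on one core cannot be transferred to the other, but two pairs do not show which feature of the cores decides the outcome, nor what the change would do on a third core.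

The compounds shown leave open which of the several differences between the two cores separates the two steps, since no pair among them changes the core in one place only. They also leave open how bromo, methyl or trifluoromethyl on the same aromatic carbon would read on either core.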